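Methoxy on the benzyl ring of compound 3

A few compounds are considered here, and "the series" means these few. Any claim that something is new, unique, unknown or untested is made for them only; others in the source may bear on it.

In an assay on CHO cells for binding affinity to Substance-P receptor (Homo sapiens) (a lower number here means a stronger inhibitor, a higher number a weaker inhibitor), compound 3 `CCCCCN(CCCCC)C(=O)N1CCN(C(=O)N(c2ccccc2)c2ccccc2)[C@H](C(=O)N(C)CCN(C)Cc2ccccc2)C1` gives 290 nM, the highest of the three numbers measured, though compound 1 `CCCCCN(CCCCC)C(=O)N1CCN(C(=O)N(c2ccccc2)c2ccccc2)[C@H](CO)C1`, which gives 280 nM, lies within the scatter of it. Compound 2 `CCCCCN(CCCCC)C(=O)N1CCN(C(=O)N(c2ccccc2)c2ccccc2)[C@H](C(=O)NCCCN(CC)CC)C1` gives 41 nM, clearly lower. Within the data shown here, the only single-change step measured is a 6.8-fold lower number from compound 1 to compound 2 (0.83 log units; beyond the scatter); it concerns the substituent on the saturated ring carbon, not the aromatic ring. Compound 4 `CCCCCN(CCCCC)C(=O)N1CCN(C(=O)N(c2ccccc2)c2ccccc2)[C@H](C(=O)N(C)CCN(C)Cc2ccccc2OC)C1` differs from compound 3 by methoxy in place of hydrogen on an aromatic carbon. Among the measured compounds shown here, no measured pair varies the benzyl ring, so the one step gives no direct guidance, and in this assay the expected step is a 1.0-fold higher number from compound 3 to compound 4 (0.01 log units; within the scatter), none beyond the scatter. Compound 4 is estimated at 300 nM, with a range from 120 nM to 750 nM.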

Compound 4, half-maximal inhibitory concentration: 17 nM
For compound 4 the middle estimate is 18-fold (1.25 log units) above the measured one; the measured number lies below the stated range.
By their numbers in this assay, from the lowest: compound 4; then compound 2; then compounds 1 and 3 (each within the scatter of the next).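

In this assay, the benzyl ring proves to be a sensitive position: methoxy in place of hydrogen on an aromatic carbon, ortho to a large group, gives a 17-fold lower number from compound 3 to compound 4 (1.23 log units; beyond the scatter), a large step for a change of 2 heavy atoms. The earlier step concerned only the substituent on the saturated ring carbon, whereas this one shows that the benzyl end of the side chain also moves the number. No measurement available here accounts for the size of this step.

From the compounds shown here alone, whether the step is specific to methoxy remains open, since fluorine, hydroxy or ethoxy at this place could be compared with it. Also open, going by these compounds, is how methoxy would read on the other carbons of the ring.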